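Swapping Methyl for Fluoro on the Core-Bound Ring

The compounds below may be only part of what the source reports. "The series", "measured", "known", "first", "only" and "open" are said of these compounds alone.

Of the compounds shown here, three sharing one core have been tested in an assay on isolated protein for inhibition of Ephrin type-A receptor 2 (Homo sapiens), read by thermal shift assay, tested at 10 uM; on this read-out lower numbers stand for weaker stabilisation of the target and higher numbers for stronger stabilisation of the target against heat. Going by the values given here, compound 1 `CC(C)(C)c1cc(NC(=O)Nc2ccc(F)cc2)n(-c2ccccc2)n1` gives -2.2 degrees C. Compound 2 `Cc1ccc(F)cc1NC(=O)Nc1cc(C(C)(C)C)nn1-c1ccccc1` gives 1.6 degrees C, and the single change between them, a number 3.8 degrees C higher from compound 1 to compound 2 (beyond the scatter), is the only step measured so far. Compound 3 `Cc1ccc(-n2nc(C(C)(C)C)cc2NC(=O)Nc2cc(C(F)(F)F)cc(C(F)(F)F)c2)cc1` gives 0.8 degrees C; among the three numbers it stands second highest, within the usual scatter of compound 2 and beyond the scatter above compound 1.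

Compound 4 `CC(C)(C)c1cc(NC(=O)Nc2cc(C(F)(F)F)cc(C(F)(F)F)c2)n(-c2ccc(F)cc2)n1` differs from compound 3 in one spot: fluoro in place of methyl on an aromatic carbon of a six-membered aromatic ring of carbon only, sitting para to a large group. Among the compounds with values here, no measured step bears on this exchange; the one step known altered the ring on the amide-type nitrogen, a different part of the molecule. With nothing pointing either way, the expected step of no change at the digits printed from compound 3 to compound 4 (within the scatter) lies within the scatter. The estimate for compound 4 in this assay is therefore 0.8 degrees C, expected to fall between -1 degrees C and 2.6 degrees C.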

Compound 4, shift of the target's melting temperature: 0.4 degrees C
The estimate for compound 4 lay 0.40 degrees C above the measured number; the range from low to high includes it.
By their numbers in this assay, from the lowest: compound 1; then compounds 4, 3 and 2 (each within the scatter of the next, the first and the last beyond it).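

In this assay, the exchange of 4-methylphenyl for 4-fluorophenyl gives a number 0.40 degrees C lower from compound 3 to compound 4 (within the scatter). Going by these compounds alone, this is the first measured exchange on this ring, at the place para to a large group, and it shows that methyl and fluoro cannot be told apart there, at least with the rest of the molecule as it stands in these two compounds. No available evidence accounts for the two groups reading alike.

As far as these compounds go, it remains open whether the same exchange would read alike with the 5-fluoro-2-methylphenyl group of compound 2 on the amide-type nitrogen. Also open, from the compounds shown here alone, is whether a quite different group at this place, such as an amine, a carboxylic acid or a longer chain, would move the number beyond the scatter.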